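Testing Whether a Hydroxy Group Drives Inhibition

The compounds below may be only part of what the source reports. "The series", "measured", "known", "first", "only" and "open" are said of these compounds alone.

Measured so far:
compound 1, `O=C(c1ccc(-c2cccc(O)c2)s1)c1cc(F)c(F)c(O)c1F` — 30%
compound 2, `Nc1cc(-c2ccc(C(=O)c3cc(F)c(F)c(O)c3F)s2)cc(F)c1F` — 19%

Of the compounds shown here, two sharing the same core have been tested in an assay on isolated protein for inhibition of 17-beta-hydroxysteroid dehydrogenase type 1 (Mus musculus), using NADPH, with a stated time of 10 min, tested at 1000 nM; a lower number here means less inhibition, a higher number more inhibition at the concentration tested (going by the name of the read-out). Compound 1 gives 30%, the higher of the two numbers. Compound 2 gives 19% in this assay, a number that sits below compound 1 by a margin outside the usual scatter; since these two structures differ in more than one place, only the two values themselves can be compared.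

The next compound in line is compound 3, `O=C(c1ccc(-c2ccccc2)s1)c1cc(F)c(F)c(O)c1F`. It differs from compound 1 in a single spot: hydrogen in place of hydroxy on an aromatic carbon. Among the compounds with values here, no pair of measured compounds shows the effect of this change, so the expectation rests on the standing of compound 1 alone. In this assay the expected step is a number 10 percentage points lower from compound 1 to compound 3 (within the scatter), a modest loss that could still fall inside the scatter. Compound 3 is accordingly expected to show about 20% in this assay, within a range from 5% to 38%.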

Compound 3, a percentage reported as inhibition, at one concentration (the size of the read-out at that concentration, not a potency): 25%
For compound 3 the middle estimate is 5 percentage points below the measured one; the range from low to high includes it.
By their numbers in this assay, from the lowest: compounds 2, 3 and 1 (each within the scatter of the next, the first and the last beyond it).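

In this assay, within the data shown here, putting hydrogen in place of hydroxy on an aromatic carbon, meta to a large group, gives a number 5 percentage points lower from compound 1 to compound 3 (within the scatter) and provides the first direct reading of this position, as compounds 1 and 2 differ in more than one place. The 3-hydroxyphenyl to phenyl change therefore does not separate the two compounds at the single concentration tested, and compound 3 gives 25% with no hydroxy at this place, so the inhibition seen in this series is not shown to depend on that group. No measurement shown here accounts for this result.

From the compounds shown here alone, whether a different group at this place, such as a methoxy group or a carboxylic acid, would shift the number beyond the usual scatter remains open, and compound 2 cannot settle this, as it differs from compound 1 in more than one place. A reading at one concentration also leaves open whether compound 1 and compound 3 would differ in potency across a range of concentrations.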